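A few compounds are considered here, and "the series" means these few. Any claim that something is new, unique, unknown or untested is made for them only; others in the source may bear on it.

Working notes on the series. The shared core is that of compound 1 `CC(Sc1nnc(-c2ccncc2)s1)C(=O)Nc1ccccc1`; compound 2 `CC(Sc1nnc(-c2ccncc2)s1)C(=O)NCc1ccc(Cl)cc1` and compound 3 `CC(Sc1nnc(-c2ccncc2)s1)C(=O)Nc1ccc(Cl)cc1Cl` carry the same core with different amide-side groups, as does the still unmeasured compound 4 `O=C(CSc1nnc(-c2ccncc2)s1)NCc1ccc(Cl)cc1`. In an ADME assay on HepG2 cells (Homo sapiens) for cytotoxicity, with a stated time of 3 days (on this read-out lower numbers stand for higher toxicity in this test and higher numbers for lower toxicity in this test), compound 1 gives > 50000 nM, which is a limit of the assay and not a number. In this assay compound 3 gives > 50000 nM, again a limit. The step that the two limits leave unreadable from compound 1 to compound 3 is therefore unreadable. For compound 2, this assay reports "not determined" (no result reported), so compound 2 stands without a number of its own, and the only anchor in the set is the limit of > 50000 nM in this assay, at which 2 of the 3 values shown sit.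

Compound 4 differs from compound 2 by hydrogen in place of methyl on a saturated chain carbon bound to a carbonyl carbon and a sulfur. Among the compounds with values here, no measured step bears on this change, and no readable step exists anywhere in the set, so no direction or size beyond the scatter can be drawn from the data. Given (the limit of > 50000 nM in this assay, at which 2 of the 3 values shown sit), compound 4 is expected in this assay to sit near 50000 nM, estimated within 20000 nM to 100000 nM, most probably reported again only as a limit.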

Compound 4, half-maximal cytotoxic concentration: > 50000 nM
Compound 4: a limit, no number (the forecaster's own chance of this, stated with the estimate: 85%); the middle value lies on the limit itself.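

In this assay compound 4 gives > 50000 nM, a limit of the assay and not a number. Within the data shown here, for compound 2 the entry is "not determined" (no result reported), so no step between compound 2 and compound 4 can be read. The compounds shown leave open whether hydrogen in place of methyl changes this read-out at all.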